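The source may hold more compounds than are shown below. What is called first, only, known or untested is meant among the compounds shown, and "the series" means these compounds.

Measured in an ADME assay on a cell-free system (plasma, Homo sapiens) for metabolic stability, tested at 1 uM; a lower number here means that the compound disappears faster, a higher number that the compound lasts longer:
- Compound 1 `C=CC(=O)N1CCN(S(=O)(=O)c2ccc(NC(=O)OCc3ccccc3)cc2)CC1`: > 6 h, a limit.
- Compound 2 `C=CC(=O)NC1CCN(S(=O)(=O)c2ccc(C(=O)NCCCc3ccccc3)cc2)CC1`: > 6 h, a limit.
- Compound 3 `C=CC(=O)NC1CCN(S(=O)(=O)c2ccc(C(=O)N(C)Cc3ccccc3)cc2)CC1`: > 6 h, a limit.

Compound 3 therefore has no exact number in this assay, and the series offers only (the limit of > 6 h in this assay, at which 3 of the 3 values shown sit). Compound 4 `C=CC(=O)NC1CCN(S(=O)(=O)c2ccc(C(=O)NC3CCCc4ccccc43)cc2)CC1` carries (1,2,3,4-tetrahydronaphthalen-1-yl)amino in place of benzyl(methyl)amino on a carbonyl carbon. Within the data shown here, the only measured step at this place is a step that the two limits leave unreadable from compound 2 to compound 3, and it gives no size to carry over. No step beyond the scatter is expected, and no direction is favoured, because of the limit of > 6 h in this assay, at which 3 of the 3 values shown sit. The expected change is a step that the limit leaves unreadable from compound 3 to compound 4. For compound 4, the estimate is 9 h, with an expected range of 5 h to 24 h.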

Compound 4, half-life: > 6 h
Compound 4 gave a limit, no number; the forecaster's own chance of this, stated with the estimate: 85%; the middle value is on the limit's open side.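

Compound 4 gives only a limit, as do compound 2 and compound 3, so no step among them can be read in this assay: the limit of > 6 h in this assay, at which 4 of the 4 values shown sit.

The compounds shown leave open how long each one actually lasts, and whether these amide groups differ at all in this assay.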